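The compounds below may be only part of what the source reports. "The series", "measured", "known", "first", "only" and "open" are said of these compounds alone.

Of the compounds shown here, two have so far been measured in an ADME assay for permeability, using PAMPA, at pH 7.4; on this read-out higher numbers stand for higher permeability and lower numbers for lower permeability. Compound 1 `O=C(NCCO)c1ccc2ccc(C(=O)c3ccccc3)c-2cc1` gives 1.8 10^-6 cm/s in this assay, and compound 2 `CN(C)C(=O)c1cn(C)c2ccccc12` gives 6.7 10^-6 cm/s. Within the data shown here, compound 1 therefore stands lowest of the two numbers, and its only neighbour, compound 2, sits higher by an amount beyond the usual scatter. Among the measured compounds shown here, no two measured compounds differ from each other in a single place, so no measured step can serve as a direct guide.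

Compound 3 `COC(=O)c1ccc2ccc(C(=O)c3ccccc3)c-2cc1` has not yet been measured in this assay. It differs from compound 1 in one place: methoxy in place of (2-hydroxyethyl)amino on a carbonyl carbon. The change sits on a carbonyl carbon whose other neighbour is an aromatic carbon, so the shared core of compound 1 is kept whole.

For the measured compounds named here, with no measured step of this kind, the expectation rests on compound 1 alone, which gives 1.8 10^-6 cm/s. The step of a 4.4-fold higher number from compound 1 to compound 3 (0.65 log units; beyond the scatter) is expected to be upward and to go beyond the scatter. Compound 3 is accordingly estimated at 8 10^-6 cm/s, within a range from 3 10^-6 cm/s to 20 10^-6 cm/s.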

Compound 3, apparent permeability in the ADME assay: 0.1 10^-6 cm/s
The estimate for compound 3 lay 80-fold (1.90 log units) above the measured number; measured number outside the range, below it.
By their numbers in the ADME assay, from the lowest: compound 3; then compound 1; then compound 2.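

At this position, on a carbonyl carbon whose other neighbour is an aromatic carbon, the ADME assay proves highly sensitive to the group attached: methoxy in place of (2-hydroxyethyl)amino gives an 18-fold lower number from compound 1 to compound 3 (1.26 log units; beyond the scatter). In a physicochemical assay for lipophilicity (on this read-out higher numbers stand for higher lipophilicity and lower numbers for lower lipophilicity), compound 1 gives 2.2 and compound 3 gives 4.7, so this single change moves the two read-outs in opposite directions. The fall in permeability therefore comes with a rise in lipophilicity, and for this pair higher lipophilicity does not go with higher permeability: the measured partition coefficient of compound 1, 2.2, and of compound 3, 4.7, a number 2.50 log units higher (beyond the scatter)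

A single change at this position cannot show which part of the exchange goes with the fall, whether the loss of the terminal hydroxyl, the loss of the amide hydrogen or the replacement of the nitrogen by oxygen. Simple methylamino or dimethylamino groups on the same carbonyl carbon would help separate these possibilities, and a carboxylic acid there would extend the comparison beyond the amide and the ester.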